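A few compounds are considered here, and "the series" means these few. Any claim that something is new, unique, unknown or untested is made for them only; others in the source may bear on it.

Measured in an in vitro ADME assay on microsomes from liver (Homo sapiens) for metabolic stability (a lower number here means slower removal, a higher number faster removal of the compound), so far, by compound:
- compound 1 `Clc1ccc(C2Cc3nccn3C2)cc1` gives 32 mL.min-1.g-1
- compound 2 `NC(=O)c1ccccc1C1Cc2nccn2C1` gives "not determined" (no result reported)
- compound 3 `COc1ccccc1C1CCc2nc[nH]c2C1` gives "not determined" (no result reported)

Compound 2 therefore has no single number to stand on, and compound 3 shares that gap. Only compound 1 supplies a figure. Next comes the unmeasured compound 4 `Clc1ccccc1C1Cc2nccn2C1`. The change is chloro in place of carbamoyl on an aromatic carbon. Going by the values given here, no measured step exists to size this change, and compound 2 offers no starting value, so neither a size nor a direction can be derived from it. The expectation instead is a value close to that of compound 1 (32 mL.min-1.g-1), which also carries chloro. In this assay compound 4 is estimated at 30 mL.min-1.g-1 (expected range 12 mL.min-1.g-1 to 70 mL.min-1.g-1).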

Compound 4, intrinsic clearance in microsomes: 18 mL.min-1.g-1
The estimate for compound 4 lay 1.7-fold (0.22 log units) above the measured number; low and high end bracket the measured number.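

Going by these compounds alone, compound 2 has no single number in this assay, so no step to compound 4 at 18 mL.min-1.g-1 can be read. On these data alone, what replacing carbamoyl with chloro does to this read-out stays open. No supporting data bear on this result.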